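Adding methylsulfonyl to a compound at the assay limit

A few compounds are considered here, and "the series" means these few. Any claim that something is new, unique, unknown or untested is made for them only; others in the source may bear on it.

Compound 1 `Fc1ccc(C2CC(c3ccc(Cl)s3)=NN2c2nc(-c3ccc(Cl)cc3)cs2)cc1`: > 500 ug/mL
Compound 2 `Cc1ccc(C2=NN(c3nc(-c4ccccc4)cs3)C(c3ccc(F)cc3)C2)s1`: > 500 ug/mL

In an ADME assay on NIH3T3 cells (Mus musculus) for cytotoxicity, read by XTT assay, with a stated time of 24 h (a lower number here means a stronger inhibitor, a higher number a weaker inhibitor), compound 2 gives > 500 ug/mL, which is a limit of the assay and not a number. Compound 1 gives > 500 ug/mL, also a limit. The whole picture so far is the limit of > 500 ug/mL in this assay, at which 2 of the 2 values shown sit.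

Compound 3 `Cc1ccc(C2=NN(c3nc(-c4ccc(S(C)(=O)=O)cc4)cs3)C(c3ccc(F)cc3)C2)s1` keeps the frame of compound 2 and changes it in one place: methylsulfonyl in place of hydrogen on an aromatic carbon. In other words, a phenyl becomes a 4-(methylsulfonyl)phenyl. Among the measured compounds shown here, no measured pair shows what this change does, so any expectation is tentative. It rests on compound 2, with its limit of > 500 ug/mL. No step beyond the usual scatter is expected, and the estimate is a number no higher from compound 2 to compound 3 (the limit leaves the size open). Compound 3 is expected near 500 ug/mL, with an estimated range from 250 ug/mL to 1000 ug/mL.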

Compound 3, half-maximal inhibitory concentration: 374 ug/mL
For compound 3 the middle estimate is 1.3-fold (0.13 log units) above the measured one; low and high end bracket the measured number.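

In this assay compound 3 gives 374 ug/mL and is the only compound shown with a number and not a limit. For compound 2 the reading of > 500 ug/mL is a limit of the assay and not a number. Turning the phenyl into a 4-(methylsulfonyl)phenyl gives an at least 1.3-fold lower number from compound 2 to compound 3 (0.12 log units; that floor lies within the scatter) and so shows only that this position can carry methylsulfonyl while the compound stays within the measurable range, with the true size of the step unknown because of where the other values sit: the limit of > 500 ug/mL in this assay, at which 2 of the 3 values shown sit.

The compounds shown leave open what an amine, a carboxylic acid or a longer chain would do in the same place on compound 2. They also leave open whether methylsulfonyl would give a measurable number on the frame of compound 1.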